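This account rests on a few compounds, and the source may have more. Where it says the series, first, only, none or still open, it means among the compounds named here.

Compounds measured in a functional assay on A-375 cells (Homo sapiens) for antiproliferative activity, read by CCK-8 assay, with a stated time of 72 h, tested at 8 uM; on this read-out higher numbers stand for a stronger effect at the one concentration tested and lower numbers for a weaker effect:
compound 1, `Nc1ccccc1NC(=O)c1ccc(CSC(=S)N2CCN(Cc3ccccn3)CC2)cc1`: 82.4%
compound 2, `Nc1ccccc1NC(=O)c1ccc(CSC(=S)N2CCN(c3ccc(Cl)cc3)CC2)cc1`: 29%
compound 3, `Nc1ccccc1NC(=O)c1ccc(CSC(=S)N2CCN(c3ccc(F)cc3)CC2)cc1`: 76.3%

Compound 3 stands second highest of the three numbers, with compound 1 nearest and compound 2 furthest. Compound 4, `N#Cc1ccc(N2CCN(C(=S)SCc3ccc(C(=O)Nc4ccccc4N)cc3)CC2)cc1`, differs from compound 3 by cyano in place of fluoro on an aromatic carbon. Going by the values given here, two measured steps bear on this place: a number 47.3 percentage points higher from compound 2 to compound 3 (beyond the scatter) was large, whereas a number 6.1 percentage points lower from compound 1 to compound 3 (within the scatter) stayed within the scatter. Among the compounds with values here, no measured step puts cyano in place of fluoro, so the direction for compound 4 is open, and a step of moderate size downward with wide uncertainty is expected, a number 21.3 percentage points lower from compound 3 to compound 4 (beyond the scatter). Compound 4 is therefore estimated to give 55% in this assay, within a range from 25% to 85%.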

Compound 4, a percentage reported as inhibition, at one concentration (the size of the read-out at that concentration, not a potency): 62.9%
For compound 4 the middle estimate is 7.9 percentage points below the measured one; the range from low to high includes it.
By their numbers in this assay, from the lowest: compound 2; then compound 4; then compounds 3 and 1 (each within the scatter of the next).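

With cyano on this aromatic carbon, the read-out in this assay lies between those of the two halogens, with a number 13.4 percentage points lower from compound 3 to compound 4 (beyond the scatter) and a number 33.9 percentage points higher from compound 2 to compound 4 (beyond the scatter) as the two steps. Unlike the 4-fluorophenyl group of compound 3, the 4-cyanophenyl group also separates from the (pyridin-2-yl)methyl group of compound 1, showing a number 19.5 percentage points lower from compound 1 to compound 4 (beyond the scatter) on the ring nitrogen. Nothing given here accounts for this order among the three groups. The compounds shown leave open where an amine, a methoxy group or a carboxylic acid on this carbon would fall, and whether the order would hold with the (pyridin-2-yl)methyl group replaced by other benzyl groups.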